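Cytotoxicity across a four-compound set, one change at a time

The source may hold more compounds than are shown below. What is called first, only, known or untested is meant among the compounds shown, and "the series" means these compounds.

Of the compounds shown here, three have been measured in an ADME assay on MT4 cells (Homo sapiens) for cytotoxicity, read by MTT assay; on this read-out higher numbers stand for lower toxicity in this test and lower numbers for higher toxicity in this test. Compound 1 `N#Cc1ccc(Nc2nccc(NC3CC3)n2)cc1` gives 1190 nM. Compound 2 `Cc1cc(NC2CCCC2)nc(Nc2ccc(C#N)cc2)n1` gives 310 nM, the lowest of the three numbers. Compound 3 `N#Cc1ccc(Nc2nccc(NC3CCCC3)n2)cc1` gives 9130 nM.

Two single changes connect them. The ring on the amine nitrogen, (cyclopropyl in place of cyclopentyl on a nitrogen on an aromatic ring), produces a 7.7-fold lower number from compound 3 to compound 1 (0.88 log units; beyond the scatter). The two cores differ by methyl in place of hydrogen on an aromatic carbon, and the reverse of that, hydrogen in place of methyl, produces a 29-fold higher number from compound 2 to compound 3 (1.47 log units; beyond the scatter). Both steps lie beyond the scatter.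

Compound 4 `Cc1cc(NC2CC2)nc(Nc2ccc(C#N)cc2)n1` is not yet measured in this assay. It differs from compound 2 by cyclopropyl in place of cyclopentyl on a nitrogen on an aromatic ring. The place of this change reads word for word as for the change from compound 3 to compound 1, so it is the same change carried onto the methyl-bearing core. The step is expected to be a 5.6-fold lower number from compound 2 to compound 4 (0.75 log units; beyond the scatter), resting on the measured 7.7-fold lower number from compound 3 to compound 1 (0.88 log units; beyond the scatter). Compound 2 already gives 310 nM. Compound 4 is therefore estimated at 55 nM, within a range expected from 15 nM to 250 nM.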

Compound 4, half-maximal cytotoxic concentration: 88 nM
The estimate for compound 4 lay 1.6-fold (0.20 log units) below the measured number; the range from low to high includes it.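

In this assay, cyclopropyl in place of cyclopentyl on the methyl-bearing core gives a 3.5-fold lower number from compound 2 to compound 4 (0.55 log units; beyond the scatter), the same direction as on the core without the methyl, and the two steps agree: the same change on two cores in this assay, a 7.7-fold lower number (0.88 log units; beyond the scatter) from compound 3 to compound 1 and a 3.5-fold lower number (0.55 log units; beyond the scatter) from compound 2 to compound 4, 2.2-fold (0.34 log units) apart, within the scatter of two such steps Methyl in place of hydrogen on an aromatic carbon, now read with cyclopropylamino in place, gives a 14-fold lower number from compound 1 to compound 4 (1.13 log units; beyond the scatter), and it too carries over from the cyclopentylamino pair: the same change on two cores in this assay, a 29-fold higher number (1.47 log units; beyond the scatter) from compound 2 to compound 3 and a 14-fold higher number (1.13 log units; beyond the scatter) from compound 4 to compound 1, 2.2-fold (0.34 log units) apart, within the scatter of two such steps Within these four compounds, each change keeps its direction and its size within the scatter when moved to the other core, but that rests on one pair of steps per change in a single cell line and shows neither the reason for the steps nor any reach beyond these two groups on each position.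

Open, going by these compounds, is whether the same holds for cyclobutyl or a longer open chain on the amine nitrogen, or for ethyl or trifluoromethyl on the aromatic carbon. Also open, on these data alone, is what happens to either step if the nitrile gives way to an amide or a carboxylic acid.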